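The compounds below may be only part of what the source reports. "The series", "measured", "known", "first", "only" and "open" are said of these compounds alone.

Compound 1 `COc1ccc(Cn2c(NCCNC(=N)N)nc(=O)n(Cc3ccc(Br)cc3)c2=O)cc1`: 0.00036 nM
Compound 2 `COc1ccc(Cn2c(NCCNC(=N)N)nc(=O)n(Cc3ccc(Cl)cc3)c2=O)cc1`: 0.004 nM
Compound 3 `COc1ccc(Cn2c(NCCNC(=N)N)nc(=O)n(Cc3ccc(C)cc3)c2=O)cc1`: 0.0044 nM

All three share one core and differ only in the group carried on one aromatic carbon, read in a functional assay on the whole organism (strain C57Bl/6) for inhibition, with Mus musculus as the target, with a stated time of 180 min, at 48 degrees C; a higher number here means that more compound is needed for the effect, a lower number that less compound is needed. Compound 3 gives the highest of the three numbers, though its gap to compound 2 is within the scatter, so those two cannot be told apart; only compound 1 stands clearly lower, a 12-fold higher number from compound 1 to compound 3 (1.09 log units; beyond the scatter). Compound 4 `COc1ccc(Cn2c(NCCNC(=N)N)nc(=O)n(Cc3ccc(F)cc3)c2=O)cc1` comes from compound 3 by one change: fluoro in place of methyl on an aromatic carbon. Within the data shown here, no measured step puts fluoro in place of anything, so the expectation rests on the neighbouring steps. The two large ones, an 11-fold higher number from compound 1 to compound 2 (1.05 log units; beyond the scatter) and a 12-fold higher number from compound 1 to compound 3 (1.09 log units; beyond the scatter), show that leaving bromo for chloro or for methyl costs much; the small step of a 1.1-fold higher number from compound 2 to compound 3 (0.04 log units; within the scatter) shows that chloro and methyl give numbers alike. Fluoro at the same place is therefore expected to land near compound 3, with an expected step of a 1.4-fold higher number from compound 3 to compound 4 (0.13 log units; within the scatter) that stays within the scatter or runs slightly higher. Compound 4 is estimated at 0.006 nM in this assay, with a range from 0.0015 nM to 0.03 nM.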

Compound 4, half-maximal effective concentration: 0.00031 nM
Compound 4: middle estimate off by 19-fold (1.29 log units), on the high side; measured number below the stated range.
By their numbers in this assay, from the lowest: compounds 4 and 1 (each within the scatter of the next); then compounds 2 and 3 (each within the scatter of the next).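

In this assay the methyl of compound 3 and the fluoro of compound 4 each bring one heavy atom to the same aromatic carbon, yet the swap gives a large step (a 14-fold lower number from compound 3 to compound 4 (1.15 log units; beyond the scatter)), and replacing the chloro of compound 2 gives another (a 13-fold lower number from compound 2 to compound 4 (1.11 log units; beyond the scatter)). Bromo is therefore no longer alone in giving a very low number, since fluoro cannot be told apart from it (a 1.2-fold lower number from compound 1 to compound 4 (0.06 log units; within the scatter)), and the halogens do not form a steady series: fluoro and bromo go together, whereas chloro goes with methyl, against any trend from fluoro through chloro to bromo. No measurement at hand accounts for why chloro parts from the other two halogens.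

On these data alone, it remains open which side other groups on this carbon would fall on, such as plain hydrogen, iodo, trifluoromethyl, methoxy or an amine, and so whether the split into two levels holds beyond these four compounds. As far as these compounds go, it is also open whether the match between fluoro and bromo would survive a change elsewhere, for example replacing the methoxy on the other aromatic ring with a hydroxyl or shortening the chain that carries the guanidine.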